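The source may hold more compounds than are shown below. What is called first, only, known or untested is meant among the compounds shown, and "the series" means these compounds.

Measured so far:
compound 1, `O=C(COc1ccc(Br)cc1)Nc1nc(-c2ccc(Br)cc2)cs1`, 41700 nM
compound 2, `O=C(COc1ccccc1)Nc1nc(-c2ccc(Br)cc2)cs1`, 37200 nM
compound 3, `O=C(COc1ccc(Br)cc1)Nc1nc(-c2ccc(Cl)cc2)cs1`, 45100 nM

All three numbers come from a functional assay on MDA-MB-468 cells (Homo sapiens) for cytotoxicity, read by MTT assay, with a stated time of 48 h; on this read-out lower numbers stand for stronger inhibition and higher numbers for weaker inhibition. They lie close together: the step of a 1.1-fold lower number from compound 1 to compound 2 (0.05 log units; within the scatter) and the step of a 1.1-fold higher number from compound 1 to compound 3 (0.03 log units; within the scatter) are both of a size that repeated testing of one and the same compound would also produce, so none of these compounds can be set above or below another.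

Compound 4, `O=C(COc1ccccc1)Nc1nc(-c2ccc(Cl)cc2)cs1`, has not yet been tested in this assay. It differs from compound 3 in one place: hydrogen in place of bromo on an aromatic carbon. Exactly the same change separates compound 1 from compound 2: hydrogen in place of bromo on an aromatic carbon, and there it gave a 1.1-fold lower number from compound 1 to compound 2 (0.05 log units; within the scatter). The two pairs sit on different cores; the cores of compound 1 and compound 3 differ as follows: chloro in place of bromo on an aromatic carbon. The surroundings of the changed place are described in identical words for both pairs, so this is the same change, carried over to a core whose own value sits within the scatter of the first, as a 1.1-fold higher number from compound 1 to compound 3 (0.03 log units; within the scatter) shows.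

The expectation for compound 4 rests on that single earlier instance, a 1.1-fold lower number from compound 1 to compound 2 (0.05 log units; within the scatter), and on the starting point that compound 3 provides with 45100 nM. For compound 4 the expected step is a 1.1-fold lower number from compound 3 to compound 4 (0.04 log units; within the scatter), which would again stay within the scatter. Compound 4 is accordingly estimated at 41000 nM, with a likely range from 25000 nM to 70000 nM.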

Compound 4, half-maximal inhibitory concentration: 55300 nM
Compound 4: middle estimate off by 1.3-fold (0.13 log units), on the low side; the measured number falls inside the stated range.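

In this assay, hydrogen in place of bromo gives a 1.2-fold higher number from compound 3 to compound 4 (0.09 log units; within the scatter), and set beside the earlier case this shows no detectable difference between the two cores: the same change on two cores in this assay, a 1.1-fold lower number (0.05 log units; within the scatter) from compound 1 to compound 2 and a 1.2-fold higher number (0.09 log units; within the scatter) from compound 3 to compound 4, 1.4-fold (0.14 log units) apart, within the scatter of two such steps. Chloro in place of bromo gives a 1.5-fold higher number from compound 2 to compound 4 (0.17 log units; within the scatter), and here too the two cores agree: the same change on two cores in this assay, a 1.1-fold higher number (0.03 log units; within the scatter) from compound 1 to compound 3 and a 1.5-fold higher number (0.17 log units; within the scatter) from compound 2 to compound 4, 1.4-fold (0.14 log units) apart, within the scatter of two such steps. Going by these compounds alone, both changes therefore carried from one core to the other without a visible shift, but every step involved is small enough to arise from repeating a measurement, so this shows only that these swaps did not move the number measurably here, not that a change with a large effect would carry over in the same way.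

All four compounds have only bromo, chloro or hydrogen at the changed places, which leaves open whether another group there, such as a methoxy group, an amine or a carboxylic acid, would produce a step beyond the scatter and whether that step would also hold on both cores. The compounds shown also leave open what a longer chain in place of the linking chain of the phenoxy group would do to the number.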